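Adding a Second Aromatic Methyl to Compound 1

This account rests on a few compounds, and the source may have more. Where it says the series, first, only, none or still open, it means among the compounds named here.

Compound 1 `Cc1ccc(C(=O)/C=C/c2ccc3c(c2)B(O)OC3)cc1` was tested in an ADME assay on L929 cells (Mus musculus) for cytotoxicity, read by resazurin assay, with a stated time of 72 h (a higher number here means a weaker inhibitor, a lower number a stronger inhibitor), and its result is a limit of the assay rather than a number: compound 1 gives > 10 ug/mL. Compound 2 `COc1ccc(C(=O)/C=C/c2ccc3c(c2)B(O)OC3)cc1` likewise reaches only a limit in this assay, giving > 10 ug/mL. Compound 3 `CCc1ccc(C(=O)/C=C/c2ccc3c(c2)B(O)OC3)cc1` also stops at a limit in this assay, giving > 10 ug/mL. All three values sit at the limit of > 10 ug/mL in this assay, at which 3 of the 3 values shown sit, so the steps among them cannot be read: a step that the two limits leave unreadable from compound 1 to compound 2, a step that the two limits leave unreadable from compound 1 to compound 3 and a step that the two limits leave unreadable from compound 2 to compound 3 are all of unreadable size. Compound 4 `Cc1ccc(C(=O)/C=C/c2ccc3c(c2)B(O)OC3)cc1C` has not yet been measured in this assay. It differs from compound 1 by methyl in place of hydrogen on an aromatic carbon. The measured steps bear on this change only in showing that every variation tried so far has left the value at the limit; none yields a readable size, so no step beyond the scatter is expected for a step that the limit leaves unreadable from compound 1 to compound 4. Compound 4 is therefore expected to give about 20 ug/mL in this assay, with a range from 8 ug/mL to 60 ug/mL, most likely again reported only as a limit.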

Compound 4, half-maximal inhibitory concentration: > 10 ug/mL
Compound 4: no number, only a limit; the forecaster's own chance of this, stated with the estimate: 80%; the middle value does not contradict the limit.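

In this assay compound 4 gives > 10 ug/mL, which is a limit of the assay and not a number. The step to it from compound 1 therefore cannot be read: the limit of > 10 ug/mL in this assay, at which 4 of the 4 values shown sit. The compounds shown leave open whether the added methyl changes the value at all, and where any of the four truly lies.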